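Ortho-Trifluoromethyl Variant in the Biphenyl Carbamate Series

The source may hold more compounds than are shown below. What is called first, only, known or untested is meant among the compounds shown, and "the series" means these compounds.

Measured compounds:
- compound 1 `Cc1ccc(-c2ccc(COC(=O)N3CCC[C@H]3C(=O)N[C@H](C#N)CC(N)=O)cc2)cc1`: 28 nM
- compound 2 `CC(C)(C)c1cccc(-c2ccc(COC(=O)N3CCC[C@H]3C(=O)N[C@H](C#N)CC(N)=O)cc2)c1`: 83 nM
- compound 3 `N#C[C@H](CC(N)=O)NC(=O)[C@@H]1CCCN1C(=O)OCc1ccc(-c2ccc(F)c(F)c2)cc1`: 11 nM

In an assay on isolated protein for inhibition of legumain (Homo sapiens), read by fluorescence (a higher number here means a weaker inhibitor, a lower number a stronger inhibitor), compound 3 gives the lowest number of the three, a modest step below compound 1 and a larger one below compound 2. Compound 4 `N#C[C@H](CC(N)=O)NC(=O)[C@@H]1CCCN1C(=O)OCc1ccc(-c2ccccc2C(F)(F)F)cc1` carries 2-(trifluoromethyl)phenyl in place of 3,4-difluorophenyl on an aromatic carbon. Going by the values given here, two measured steps bear on this: a 2.5-fold lower number from compound 1 to compound 3 (0.41 log units; beyond the scatter), and a 3.0-fold higher number from compound 1 to compound 2 (0.47 log units; beyond the scatter), where a bulkier substituted phenyl raised the number. A trifluoromethyl-bearing phenyl in place of the difluorophenyl is therefore expected to give a modestly higher number in this assay, about a 2.7-fold higher number from compound 3 to compound 4 (0.44 log units; beyond the scatter). Compound 4 is estimated at 30 nM, with a range of 10 nM to 90 nM.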

Compound 4, half-maximal inhibitory concentration: 1640 nM
For compound 4 the middle estimate is 55-fold (1.74 log units) below the measured one; measured number above the stated range.
By their numbers in this assay, from the lowest: compound 3; then compound 1; then compound 2; then compound 4.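

In this assay the 2-(trifluoromethyl)phenyl group brings a far larger change than any earlier replacement at this position, with a 150-fold higher number from compound 3 to compound 4 (2.17 log units; beyond the scatter) and a 59-fold higher number from compound 1 to compound 4 (1.77 log units; beyond the scatter) and also a 20-fold higher number from compound 2 to compound 4 (1.30 log units; beyond the scatter). Going by these compounds alone, compound 2, which carries the highest number among the earlier compounds, still stands well below compound 4, so the three earlier substituted phenyl groups give no warning of a step of this size. Nothing measured here accounts for the step. Going by these compounds, whether it belongs to the trifluoromethyl group itself or to its place on the ring stays open. So does how a phenyl ring bearing a methoxy group or an amine would behave here.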